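Hydroxyphenyl to chlorophenyl on the hydrazone carbon

This account rests on a few compounds, and the source may have more. Where it says the series, first, only, none or still open, it means among the compounds named here.

Compound 3 `CC1=CC[C@H](C(C)(C)NC(=S)N/N=C/c2ccccc2O)CC1` stands lowest of the two numbers given: in an ADME assay on Vero cells (Chlorocebus sabaeus) for inhibition, read by sulforhodamine B assay, with a stated time of 48 h (a higher number here means a weaker inhibitor of growth, a lower number a stronger inhibitor of growth), compound 3 gives 3100 nM. Compound 2 `CC1=CC[C@H](C(C)(C)NC(=S)NN)CC1` gives 49500 nM in this assay. Compound 1 `CC1=CC[C@H](C(C)(C)N=C=S)CC1` gives > 100000 nM in this assay, which is a limit and not a number (the limit of > 100000 nM in this assay, at which 1 of the 3 values shown sits). Among the measured compounds shown here, the only measured step, an at least 2.0-fold lower number from compound 1 to compound 2 (0.30 log units; that floor lies within the scatter), alters the group on the saturated chain carbon and so does not bear on the part changed here. Compound 4 `CC1=CC[C@H](C(C)(C)NC(=S)N/N=C/c2ccc(Cl)cc2)CC1` differs from compound 3 by 4-chlorophenyl in place of 2-hydroxyphenyl on a carbon with a double bond to nitrogen. For the measured compounds named here, with no measured step covering this exchange, no direction beyond the scatter is expected and the range is kept wide. Compound 4 is thus expected near 3500 nM in this assay, between 1000 nM and 12000 nM. The expected step is a 1.1-fold higher number from compound 3 to compound 4 (0.05 log units; within the scatter).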

Compound 4, concentration for 50% growth inhibition: 70000 nM
For compound 4 the middle estimate is 20-fold (1.30 log units) below the measured one; the whole stated range lies below it.
By their numbers in this assay, from the lowest: compound 3; then compounds 2 and 4 (each within the scatter of the next). At a limit, above all of these: compound 1.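

Putting 4-chlorophenyl in place of 2-hydroxyphenyl on a carbon with a double bond to nitrogen gives a 23-fold higher number from compound 3 to compound 4 (1.35 log units; beyond the scatter) in this assay. Among the compounds shown here, this shows that growth inhibition depends strongly on the group carried at this position, which no earlier step had touched. Nothing at hand accounts for the size of this step.

The compounds shown leave open whether the exchange of the hydroxyl for the chlorine or the change in ring position matters more. Plain phenyl, 2-chlorophenyl and 4-hydroxyphenyl would separate these, and 2-aminophenyl would test another group at the hydroxyl's place.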